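Shortening the Propyl Chain of Compound 3

A few compounds are considered here, and "the series" means these few. Any claim that something is new, unique, unknown or untested is made for them only; others in the source may bear on it.

Compound 1 `COc1ncc(-c2ccc3nc(NC(=O)NCCN4CCCCC4)nn3c2)cc1NS(=O)(=O)c1ccc(F)cc1` gives 610 nM
Compound 2 `COc1ncc(-c2ccc3nc(NC(=O)NCCN(C)C)nn3c2)cc1NS(=O)(=O)c1ccc(F)cc1` gives 800 nM
Compound 3 `CCCNC(=O)Nc1nc2ccc(-c3cnc(OC)c(NS(=O)(=O)c4ccc(F)cc4)c3)cn2n1` gives 220 nM

In a functional assay on A549 cells (Homo sapiens) for cytotoxicity, read by MTT assay, with a stated time of 72 h (on this read-out higher numbers stand for weaker inhibition and lower numbers for stronger inhibition), compound 3 gives 220 nM as the lowest of the three numbers. Compound 4 `CNC(=O)Nc1nc2ccc(-c3cnc(OC)c(NS(=O)(=O)c4ccc(F)cc4)c3)cn2n1` shortens its propyl chain to methyl (hydrogen in place of ethyl on a saturated chain carbon bound to an amide-type nitrogen), with hydrogen in place of ethyl on a saturated chain carbon bound to an amide-type nitrogen.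

Going by the values given here, no measured step makes this exact change. The closest evidence comes from the same chain. Methyl in place of piperidin-1-yl gave a modest step (a 2.8-fold lower number from compound 1 to compound 3 (0.44 log units; beyond the scatter)), and methyl in place of dimethylamino gave another (a 3.6-fold lower number from compound 2 to compound 3 (0.56 log units; beyond the scatter)). Dimethylamino in place of piperidin-1-yl stayed within the scatter (a 1.3-fold higher number from compound 1 to compound 2 (0.12 log units; within the scatter)). None of these steps shortens a plain alkyl chain, so they offer only weak guidance. No step beyond the scatter is expected in this assay, and no direction is firmly supported. The expected step is small (a 1.2-fold higher number from compound 3 to compound 4 (0.07 log units; within the scatter)). Compound 4 is estimated at 260 nM (expected range 90 nM to 750 nM).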

Compound 4, half-maximal inhibitory concentration: 230 nM
Beside the measured number, compound 4's estimate is 1.1-fold (0.05 log units) above it, within the range that was stated.
By their numbers in this assay, from the lowest: compounds 3 and 4 (each within the scatter of the next); then compounds 1 and 2 (each within the scatter of the next).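

In this assay, going by these compounds alone, the first plain alkyl change at this position, propyl to methyl, makes no real difference: a 1.0-fold higher number from compound 3 to compound 4 (0.02 log units; within the scatter). Compound 4 therefore sits with compound 3, apart from the chains carrying dimethylamino or piperidin-1-yl, with a 3.5-fold lower number from compound 2 to compound 4 (0.54 log units; beyond the scatter) and a 2.7-fold lower number from compound 1 to compound 4 (0.42 log units; beyond the scatter), so this separation no longer rests on a single plain alkyl chain. Nothing measured here explains either the lack of change between the two alkyl chains or the gap to the two amine-bearing chains.

Only methyl and propyl appear among the plain chains, so the picture cannot be stretched beyond those two. Still open, from the compounds shown here alone, is how a longer chain such as hexyl, or a chain ending in a carboxylic acid, would behave at this position.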